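The compounds below may be only part of what the source reports. "The series", "measured", "known", "first", "only" and "open" are said of these compounds alone.

Working notes on the cyclohexanone series

Among the measured compounds shown here, compound 3 `COc1cccc(/C=C2\CCC/C(=C\c3cc(OC)c(OC)c(OC)c3)C2=O)c1OC` sits second highest of the three numbers so far in an ADME assay on NHDF cells (Homo sapiens) for cytotoxicity (on this read-out higher numbers stand for weaker inhibition and lower numbers for stronger inhibition), where compound 3 gives 18800 nM. Its nearest neighbour is compound 1 `COc1cc(/C=C2\CCC/C(=C\c3cccc(O)c3)C2=O)cc(OC)c1OC`, which in this assay gives 25300 nM; the gap a 1.3-fold lower number from compound 1 to compound 3 (0.13 log units; within the scatter) lies within the scatter. Furthest is compound 2 `COc1cc(/C=C2\CCC/C(=C\c3ccc(F)c(F)c3)C2=O)cc(OC)c1OC`, which gives 11100 nM; that gap, a 1.7-fold higher number from compound 2 to compound 3 (0.23 log units; within the scatter), is also within the scatter.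

The next step goes to compound 4 `COc1cc(/C=C2\CCC/C(=C\c3ccc(O)c(Cl)c3)C2=O)cc(OC)c1OC`, where the change is 3-chloro-4-hydroxyphenyl in place of 2,3-dimethoxyphenyl on a double-bonded chain carbon bound to a double-bonded ring carbon.

Bearing steps: swapping the aryl group has moved the number only modestly at most. The step of a 2.3-fold lower number from compound 1 to compound 2 (0.36 log units; beyond the scatter) is the largest seen, while a 1.3-fold lower number from compound 1 to compound 3 (0.13 log units; within the scatter) and a 1.7-fold higher number from compound 2 to compound 3 (0.23 log units; within the scatter) stay within the scatter. The change to compound 4 brings back a phenol bearing a single hydroxyl, as in compound 1, so a step in this assay of no more than the scatter is expected, with no firm direction.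

For compound 4 the expected value in this assay is 19000 nM, range 9000 nM to 40000 nM, meaning an expected step of a 1.0-fold higher number from compound 3 to compound 4 (0.00 log units; within the scatter).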

Compound 4, half-maximal inhibitory concentration: 6900 nM
Compound 4: middle estimate off by 2.8-fold (0.44 log units), on the high side; measured number outside the range, below it.
By their numbers in this assay, from the lowest: compounds 4, 2, 3 and 1 (each within the scatter of the next, the first and the last beyond it).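

In this assay, this place on a double-bonded chain carbon bound to a double-bonded ring carbon shows a wider spread than the earlier aryl swaps did: 3-chloro-4-hydroxyphenyl gives steps beyond the scatter against both 2,3-dimethoxyphenyl (a 2.7-fold lower number from compound 3 to compound 4 (0.44 log units; beyond the scatter)) and 3-hydroxyphenyl (a 3.7-fold lower number from compound 1 to compound 4 (0.56 log units; beyond the scatter)). A hydroxyl on the aryl group therefore does not by itself set the number, since compound 1 and compound 4 both carry one. The step to the 3,4-difluorophenyl group (a 1.6-fold lower number from compound 2 to compound 4 (0.21 log units; within the scatter)) stays within the scatter, so these two halogen-bearing aryl groups cannot be separated here, and nothing measured on these compounds explains the shift.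

Still open, from the compounds shown here alone, is whether the chlorine, the hydroxyl placement or the pair accounts for the lower number. The compounds shown also leave open how an amine or a carboxylic acid on the aryl group would read.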